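The compounds below may be only part of what the source reports. "The series", "measured", "known", "first", "only" and "open" are said of these compounds alone.

For the measured compounds named here, in a functional assay on HL-60 cells (Homo sapiens) for antiproliferative activity, read by MTT assay, with a stated time of 72 h (on this read-out higher numbers stand for weaker inhibition and lower numbers for stronger inhibition), compound 3 `Cc1ccc(S(=O)(=O)N(C)c2ccc3[nH]c(-c4n[nH]c5ccccc45)cc3n2)cc1` gives 3030 nM, the lowest of the three numbers so far, though compound 1 `COc1ccc(C(=O)N(C)c2ccc3[nH]c(-c4n[nH]c5ccccc45)cc3n2)cc1` at 3320 nM and compound 2 `CN(C(=O)c1ccco1)c1ccc2[nH]c(-c3n[nH]c4ccccc34)cc2n1` at 4540 nM both sit within the scatter of it. Compound 4 `CN(C(=O)Nc1ccccc1)c1ccc2[nH]c(-c3n[nH]c4ccccc34)cc2n1` has not yet been measured; it differs from compound 3 by phenylcarbamoyl in place of (4-methylphenyl)sulfonyl on a nitrogen on an aromatic ring. The group on that nitrogen has already been varied twice: a 1.1-fold lower number from compound 1 to compound 3 (0.04 log units; within the scatter) and a 1.5-fold lower number from compound 2 to compound 3 (0.18 log units; within the scatter), both within the scatter, as is a 1.4-fold higher number from compound 1 to compound 2 (0.14 log units; within the scatter). Three groups of quite different make-up on this nitrogen leave the read-out of this assay where it was, so a fourth swap there is expected to move it little; the expected step is a 1.2-fold higher number from compound 3 to compound 4 (0.06 log units; within the scatter). Compound 4 is therefore estimated at 3500 nM, with a range of 1500 nM to 8000 nM.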

Compound 4, half-maximal inhibitory concentration: 8.3 nM
Compound 4: the middle estimate sits 420-fold (2.62 log units) above what was measured, and the stated range ends above it.
By their numbers in this assay, from the lowest: compound 4; then compounds 3, 1 and 2 (each within the scatter of the next).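

In this assay the group on a nitrogen on an aromatic ring turns out to be far from neutral: phenylcarbamoyl in place of (4-methylphenyl)sulfonyl gives a large step (a 370-fold lower number from compound 3 to compound 4 (2.56 log units; beyond the scatter)). Anilino on the carbonyl carbon also gives large steps against furan-2-yl (a 550-fold lower number from compound 2 to compound 4 (2.74 log units; beyond the scatter)) and 4-methoxyphenyl (a 400-fold lower number from compound 1 to compound 4 (2.60 log units; beyond the scatter)), and among these four compounds only phenylcarbamoyl carries a hydrogen-bond donor. No evidence bearing on the size of this change is available. Still open, as far as these compounds go, is whether the amide hydrogen itself counts, which a methyl group on that anilino nitrogen would address. A chlorine on its phenyl ring or a benzylamino group on the carbonyl carbon would show how much of the phenylcarbamoyl group can vary.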